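Methyl in place of hydrogen on the fused ring nitrogen

A few compounds are considered here, and "the series" means these few. Any claim that something is new, unique, unknown or untested is made for them only; others in the source may bear on it.

For the measured compounds named here, in a functional assay on U-87MG ATCC cells for antiproliferative activity against U-87 MG (Homo sapiens), read by MTT assay, with a stated time of 72 h (a lower number here means a stronger inhibitor, a higher number a weaker inhibitor), compound 2 `COc1ccc(-n2c(=O)c(C(=O)Nc3ccc(Oc4ccnc5[nH]ccc45)cc3)cc3cccnc32)cc1` gives 2350 nM, the only number reported among the three measured entries; compound 1 `O=C(Nc1ccc(Oc2ccnc3[nH]ccc23)cc1)c1cc2cccnc2n(-c2ccc(Br)cc2)c1=O` is recorded as "not determined" (no result reported) and compound 3 `COc1ccc(-n2c(=O)c(C(=O)Nc3ccc(Oc4ccnc5[nH]ccc45)c(F)c3)cc3cccnc32)cc1` is recorded as "not determined" (no result reported) in this assay. Compound 4 `COc1ccc(-n2c(=O)c(C(=O)Nc3ccc(Oc4ccnc5c4ccn5C)cc3)cc3cccnc32)cc1` is the next step from compound 2: methyl in place of hydrogen on an aromatic nitrogen. Going by the values given here, no pair of measured compounds shows what such a change does here, so the direction rests on expectation alone. Compound 4 is expected to be weaker, with the step from compound 2 estimated at a 3.4-fold higher number from compound 2 to compound 4 (0.53 log units; beyond the scatter), beyond the usual scatter. On that basis compound 4 is estimated at 8000 nM in this assay, within a range from 2000 nM to 30000 nM.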

Compound 4, half-maximal inhibitory concentration: 5150 nM
Estimate against measurement, compound 4: 1.6-fold (0.19 log units) above; low and high end bracket the measured number.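

With methyl in place of hydrogen on the aromatic nitrogen, this assay shows a 2.2-fold higher number from compound 2 to compound 4 (0.34 log units; beyond the scatter). For the compounds shown here, this is the first measured step at this position, and it shows that the hydrogen on this nitrogen can be replaced at a modest cost, with a numerical result retained. Nothing available explains why the number rises.

From the compounds shown here alone, whether an ethyl group, a longer chain or a chain ending in an amine on this nitrogen would move the number further remains open. Also open, going by these compounds, is whether methyl would have the same effect in compound 1 or compound 3.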